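Sulfonamide series: what to expect of compound 4

The source may report more compounds than this note shows. Statements on the series, on what has been measured and on what is new or still open speak of the compounds shown alone.

compound 1 `Cc1cccc(S(=O)(=O)Nc2ccc(-c3nc4ccccc4o3)cc2)c1` — in an assay on isolated protein for inhibition of malate dehydrogenase, mitochondrial (Sus scrofa), with stated times of 45 min and 30 min (a higher number here means a weaker inhibitor, a lower number a stronger inhibitor), compound 1 gives > 63000 nM, a limit of the assay.
compound 2 `O=S(=O)(Nc1ccc(-c2nc3ccccc3o2)cc1)c1cccc(C(F)(F)F)c1` — in this assay compound 2 gives > 63000 nM, a limit of the assay.
compound 3 `O=S(=O)(Nc1ccc2oc(-c3ccccc3)nc2c1)c1cccc(F)c1` — in this assay compound 3 gives > 63000 nM, a limit of the assay.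

Compound 1 stands at a limit only, and the two further values are limits as well; all three sit at the limit of > 63000 nM in this assay, at which 3 of the 3 values shown sit. Going by the values given here, the one step between measured compounds that differ in a single place, a step that the two limits leave unreadable from compound 1 to compound 2, has a limit at each end and gives no readable size. Compound 4 `O=S(=O)(Nc1ccc(-c2nc3ccccc3o2)cc1)c1ccc(Cl)cc1` differs from compound 1 by 4-chlorophenyl in place of 3-methylphenyl on a sulfonyl sulfur. Among the compounds with values here, no measured step bears on this change, and no compound has yet produced a number in this assay. The expectation is therefore that compound 4 also returns a limit rather than a number, which amounts to an expected step that the limit leaves unreadable from compound 1 to compound 4. The estimate for compound 4 in this assay is 100000 nM, with a range from 40000 nM to 300000 nM.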

Compound 4, half-maximal inhibitory concentration: > 63000 nM
Compound 4 ended at the assay's limit; the forecaster's own chance of this, stated with the estimate: 85%; the middle value lies beyond the limit too.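

Compound 1 and compound 4 both stand at a limit of the assay in this assay, so no step between them can be read: the limit of > 63000 nM in this assay, at which 4 of the 4 values shown sit.

The compounds shown leave open which change, if any, to the group on the sulfonyl sulfur or to the shared core would give a readable number in this assay.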